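The compounds below may be only part of what the source reports. "The series", "measured", "known", "first", "only" and "open" are said of these compounds alone.

Measured compounds:
- compound 1 `COc1cccc(NC(=O)COc2ccc3cc(/C=C4/SC(=O)NC4=O)ccc3c2)c1` — 1600 nM
- compound 2 `O=C(COc1ccc2cc(/C=C3/SC(=O)NC3=O)ccc2c1)Nc1ccccn1` — 17000 nM
- compound 3 `Cc1cc(Br)ccc1NC(=O)COc1ccc2cc(/C=C3/SC(=O)NC3=O)ccc2c1` — 550 nM

Three amides on a shared core have been measured in an assay on isolated protein for inhibition of histone deacetylase 4 (Homo sapiens), with a stated time of 1 h; a lower number here means a stronger inhibitor, a higher number a weaker inhibitor. Compound 3 stands lowest of the three; its nearest neighbour is compound 1, from which the step is a 2.9-fold lower number from compound 1 to compound 3 (0.46 log units; beyond the scatter), and its furthest is compound 2, from which the step is a 31-fold lower number from compound 2 to compound 3 (1.49 log units; beyond the scatter). The remaining step, an 11-fold higher number from compound 1 to compound 2 (1.03 log units; beyond the scatter), shows that swapping the aryl group on the amide-type nitrogen for a pyridin-2-yl costs a great deal.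

Compound 4 `O=C(COc1ccc2cc(/C=C3/SC(=O)NC3=O)ccc2c1)Nc1ccc(F)cc1` has not yet been measured. It differs from compound 3 in one place: 4-fluorophenyl in place of 4-bromo-2-methylphenyl on an amide-type nitrogen. All three measured steps bear on this position, since each of them also exchanges the group on the amide-type nitrogen. Two carbon-only rings, those of compound 1 and compound 3, lie within a modest step of each other, while the pyridin-2-yl of compound 2 sits far away. Compound 4 keeps a carbon-only ring, so a modest rise in this assay is expected rather than a large one, about a 2.2-fold higher number from compound 3 to compound 4 (0.34 log units; beyond the scatter). On that basis compound 4 is estimated at 1200 nM, with a range from 400 nM to 4000 nM.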

Compound 4, half-maximal inhibitory concentration: 1600 nM
Estimate against measurement, compound 4: 1.3-fold (0.12 log units) below, and the stated range covers the measured number.
By their numbers in this assay, from the lowest: compound 3; then compounds 1 and 4 (each within the scatter of the next); then compound 2.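

In this assay, within the data shown here, the exchange of 3-methoxyphenyl for 4-fluorophenyl on the amide-type nitrogen gives no change at the digits printed from compound 1 to compound 4 (within the scatter) and sits within the scatter, so two carbon-only rings with different substituents now read alike at this position, where the earlier compounds offered only one ring at that level. The move away from 4-bromo-2-methylphenyl gives a 2.9-fold higher number from compound 3 to compound 4 (0.46 log units; beyond the scatter) in the same assay, which leaves that group as the only one of the four with a number clearly lower than all the others. The pyridin-2-yl group now stands apart from a second carbon-only ring as well, with an 11-fold lower number from compound 2 to compound 4 (1.03 log units; beyond the scatter) as the step, and all three carbon-only rings lie well below it.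

The bromine and the methyl leave together in the change to 4-fluorophenyl, so the compounds shown do not separate them, and how a phenyl ring carrying a carboxylic acid or an amine, or a benzyl group with its longer chain, would read at this position stays open. Nothing measured here offers an explanation for any of these steps.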